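1-Benzofuran-2-yl for furan-3-yl: working notes on compound 3

The source may hold more compounds than are shown below. What is called first, only, known or untested is meant among the compounds shown, and "the series" means these compounds.

Compound 1 `COc1ncnc2c1c(-c1cc3ccccc3o1)cn2[C@@H]1O[C@H](CO)[C@@H](O)[C@H]1O`: 14500 nM
Compound 2 `COc1nc(N)nc2c1c(-c1ccoc1)cn2[C@@H]1O[C@H](CO)[C@@H](O)[C@H]1O`: > 20000 nM, a limit

All values come from a functional assay on HCT-116 cells (Homo sapiens), read by MTT assay, with a stated time of 72 h; a lower number here means a stronger inhibitor, a higher number a weaker inhibitor. Compound 2 gives no number, only the limit > 20000 nM. Compound 3 `COc1nc(N)nc2c1c(-c1cc3ccccc3o1)cn2[C@@H]1O[C@H](CO)[C@@H](O)[C@H]1O` differs from compound 2 by having 1-benzofuran-2-yl in place of furan-3-yl on an aromatic carbon. Among the measured compounds shown here, no measured pair shows this change directly. For the measured compounds named here, compound 1, the only measured compound with 1-benzofuran-2-yl, gives 14500 nM, so a modest move towards stronger inhibition is expected. The expected step is an at least 1.6-fold lower number from compound 2 to compound 3 (0.22 log units; that floor lies within the scatter). For compound 3 the estimated value is 12000 nM, with an expected range of 4000 nM to 20000 nM.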

Compound 3, half-maximal inhibitory concentration: > 20000 nM
Compound 3: no number, only a limit; the forecaster's own chance of this, stated with the estimate: 30%; middle value at least 1.6-fold (0.22 log units) from the limit.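

Compound 3, like compound 2, gives only a limit and not a number, so the step between them cannot be read and 1-benzofuran-2-yl in place of furan-3-yl shows no readable gain at this position. Among the compounds shown here, the one readable change is amino in place of hydrogen on an aromatic carbon, in this assay: an at least 1.3-fold higher number from compound 1 to compound 3 (0.13 log units; that floor lies within the scatter). Readings for the amino compounds are confined by a single limit: the limit of > 20000 nM in this assay, at which 2 of the 3 values shown sit.

Open, going by these compounds, is whether phenyl in place of 1-benzofuran-2-yl on the same aromatic carbon would give a number in this assay with the amino group present.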